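The source may hold more compounds than are shown below. What is called first, only, known or untested is meant among the compounds shown, and "the series" means these compounds.

Compound 1 `CCOC(=O)C(=Cc1c(-c2ccccc2)[nH]c2ccccc12)C(=O)OCC`: 7600 nM
Compound 2 `O=C(/C(=C\c1c(-c2ccccc2)[nH]c2ccccc12)S(=O)(=O)c1ccccc1)c1ccccc1`: 3500 nM

Both compounds were tested in a functional assay on SF-295 cells (Homo sapiens) for inhibition, read by sulforhodamine B assay, with a stated time of 48 h; on this read-out higher numbers stand for weaker inhibition of growth and lower numbers for stronger inhibition of growth. Compound 2 gives the lower of the two numbers, and the gap to compound 1 lies beyond the usual scatter of this assay. Compound 3 `N#C/C(=C\c1c(-c2ccccc2)[nH]c2ccccc12)S(=O)(=O)c1ccccc1` has not yet been measured. It differs from compound 2 in one place: cyano in place of benzoyl on a double-bonded chain carbon bound to a double-bonded chain carbon and a sulfonyl sulfur. Going by the values given here, no measured pair shows this change, so the step is estimated as a 1.4-fold lower number from compound 2 to compound 3 (0.15 log units; within the scatter), a small move toward stronger inhibition of growth that may not clear the scatter. Compound 3 is therefore expected to give 2500 nM, within a range from 600 nM to 10000 nM.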

Compound 3, concentration for 50% growth inhibition: 2400 nM
Beside the measured number, compound 3's estimate is 1.0-fold (0.02 log units) above it; the range from low to high includes it.
By their numbers in this assay, from the lowest: compounds 3 and 2 (each within the scatter of the next); then compound 1.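

On the double-bonded chain carbon bound to a double-bonded chain carbon and a sulfonyl sulfur, cyano in place of benzoyl (a 1.5-fold lower number from compound 2 to compound 3 (0.16 log units; within the scatter)) stays within the scatter of this assay. The six-membered aromatic ring of benzoyl can therefore go without a clear change in this read-out, so this position does not depend on that ring here. No supporting measurement is available to explain this result. Still open, as far as these compounds go, is how a carboxylic acid, an amine or a longer alkyl chain at this position would read.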